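A few compounds are considered here, and "the series" means these few. Any claim that something is new, unique, unknown or untested is made for them only; others in the source may bear on it.

Measured so far:
compound 1, `Cc1ccc(S(=O)(=O)Nc2ccc(-c3nc4ccccc4o3)cc2)cc1`: > 63000 nM
compound 2, `Cc1ccccc1S(=O)(=O)Nc1ccc2oc(-c3ccccc3)nc2c1`: > 63000 nM

In an assay on isolated protein for inhibition of malate dehydrogenase, mitochondrial (Sus scrofa), with stated times of 45 min and 30 min (a higher number here means a weaker inhibitor, a lower number a stronger inhibitor), compound 2 gives > 63000 nM, which is a limit of the assay and not a number. Compound 1 also gives > 63000 nM, again a limit. So compound 2 stands at the limit of > 63000 nM in this assay, at which 2 of the 2 values shown sit, and nothing separates it from compound 1 on the numbers shown. Compound 3, `O=S(=O)(Nc1ccc2oc(-c3ccccc3)nc2c1)c1ccccc1F`, differs from compound 2 by fluoro in place of methyl on an aromatic carbon. Among the measured compounds shown here, no measured step covers such a change. Compound 3 is expected to give 100000 nM in this assay, between 40000 nM and 300000 nM. The expected step is a step that the limit leaves unreadable from compound 2 to compound 3, none beyond the scatter, and most likely the assay again reports only a limit.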

Compound 3, half-maximal inhibitory concentration: > 63000 nM
Compound 3: a limit, no number (the forecaster's own chance of this, stated with the estimate: 85%); the middle value is on the limit's open side.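

The change of methyl to fluoro from compound 2 to compound 3 cannot be read, because both give a limit and no number: the limit of > 63000 nM in this assay, at which 3 of the 3 values shown sit.

The compounds shown leave open which change, if any, would give a measurable inhibition.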